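A few compounds are considered here, and "the series" means these few. Any claim that something is new, unique, unknown or untested is made for them only; others in the source may bear on it.

Measured so far in an assay on isolated protein for inhibition of Gonadotropin-releasing hormone receptor (Rattus norvegicus); a lower number here means a stronger inhibitor, a higher number a weaker inhibitor:
compound 1 `CCCCn1c(SCc2cc([N+](=O)[O-])ccc2OC)nc2cc(NC(=O)NC(C)(C)C)ccc21` – 330 nM
compound 2 `COc1ccc([N+](=O)[O-])cc1CSc1nc2cc(NC(=O)NC(C)(C)C)ccc2n1C(C)C` – 62 nM

Among the measured compounds shown here, compound 2 stands lowest of the two numbers in this assay; its nearest neighbour is compound 1, and the only measured step, a 5.3-fold lower number from compound 1 to compound 2 (0.73 log units; beyond the scatter), separates them. Compound 3 `COc1ccc([N+](=O)[O-])cc1CSc1nc2cc(NC(=O)NC3CC3)ccc2n1C(C)C` keeps the core of compound 2 and differs from it in one place: cyclopropyl in place of tert-butyl on an amide-type nitrogen. For the measured compounds named here, no measured step bears on this change. Going by the values given here, the single step known, a 5.3-fold lower number from compound 1 to compound 2 (0.73 log units; beyond the scatter), concerns the alkyl on the aromatic nitrogen and says nothing about the group on the amide-type nitrogen. Going by these compounds, with nothing to lean on, no step beyond the scatter is expected in this assay, and either direction remains open. Compound 3 is therefore estimated at 90 nM in this assay, with a range of 30 nM to 300 nM. That estimate amounts to an expected step of a 1.5-fold higher number from compound 2 to compound 3 (0.16 log units; within the scatter).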

Compound 3, half-maximal inhibitory concentration: 1600 nM
Compound 3: middle estimate off by 18-fold (1.25 log units), on the low side; the measured number lies above the stated range.
By their numbers in this assay, from the lowest: compound 2; then compound 1; then compound 3.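

The group on the amide-type nitrogen matters strongly in this assay: replacing tert-butyl with cyclopropyl gives a 26-fold higher number from compound 2 to compound 3 (1.41 log units; beyond the scatter). The change is small in count, 4 heavy carbon atoms leaving and 3 entering together with a three-membered ring, and neither group has hydrogen-bond donors or acceptors, so those counts alone do not predict the size of the step. Among the compounds shown here, this step is also larger than a 5.3-fold lower number from compound 1 to compound 2 (0.73 log units; beyond the scatter), the only other step, at the alkyl on the aromatic nitrogen; nothing measured here explains the loss.

Going by these compounds, it remains open whether isopropyl, cyclobutyl or 1-methylcyclopropyl on the amide-type nitrogen would stay close to tert-butyl or fall toward cyclopropyl. On these data alone, whether the step would have the same size with butyl on the aromatic nitrogen also remains open.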